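The source may hold more compounds than are shown below. What is called first, only, known or untested is meant among the compounds shown, and "the series" means these compounds.

Working notes on the series. Compound 1 `Cc1cc(C)c(S(=O)(=O)N2CCC(N3CCC(C)CC3)CC2)c(C)c1` is one of three measured members in an ADME assay on HCT-116 cells (Homo sapiens) for cytotoxicity, read by CellTiter-Glo, with a stated time of 72 h; on this read-out lower numbers stand for stronger inhibition and higher numbers for weaker inhibition. In this assay compound 1 gives > 5000 nM, which is a limit of the assay and not a number. Compound 2 `CC1CCN(C2CCN(S(=O)(=O)c3ccc(Cl)cc3Cl)CC2)CC1` belongs to the same set; in this assay compound 2 gives > 5000 nM, also a limit. Compound 3 `Cc1ccc(C#N)c(S(=O)(=O)N2CCC(N3CCC(C)CC3)CC2)c1` completes the measured set; in this assay compound 3 gives > 5000 nM, once more a limit. Compound 1 therefore stands only at the limit of > 5000 nM in this assay, at which 3 of the 3 values shown sit. Going by the values given here, no step between measured compounds can be drawn from these entries, and no compound can be ordered against another.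

The unmeasured compound 4 `Cc1cc(C)c(S(=O)(=O)N2CCC(N3CCCCCC3)CC2)c(C)c1` keeps the core of compound 1 and is built from the same atoms, joined differently: azepan-1-yl in place of 4-methylpiperidin-1-yl on a saturated ring carbon. A seven-membered non-aromatic ring with 1 hetero atom thus takes the place of a six-membered non-aromatic ring with 1 hetero atom on the saturated ring carbon.

Since every measured value sits at the limit, no movement beyond the scatter is expected in this assay from this change, in either direction. Compound 4 is expected to give about 8000 nM, within 3000 nM to 30000 nM, and most likely to be reported as a limit again. The step this estimate means, a step that the limit leaves unreadable from compound 1 to compound 4, is expected to stay within the scatter.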

Compound 4, half-maximal inhibitory concentration: > 5000 nM
Compound 4 was reported as a limit; the forecaster's own chance of this, stated with the estimate: 80%; the middle value lies beyond the limit too.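

In this assay compound 4 gives > 5000 nM, which is a limit of the assay and not a number. Going by these compounds alone, compound 1 also stands at a limit, so no step from compound 1 to compound 4 can be read. The compounds shown leave open how any of them would order against another in this assay: the limit of > 5000 nM in this assay, at which 4 of the 4 values shown sit.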